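Phenyl ether change from compound 3 to compound 4

The source may hold more compounds than are shown below. What is called first, only, known or untested is meant among the compounds shown, and "the series" means these compounds.

Compound 1 `Cc1nn(C)c(Oc2ccccc2F)c1/C=N\CCCCCCOc1cc2oc(=O)cc(C)c2cc1Cl`: > 25000 nM in a functional assay on U-87MG ATCC cells for antiproliferative activity against U-87 MG (Homo sapiens), read by MTT assay, with a stated time of 72 h (on this read-out higher numbers stand for weaker inhibition and lower numbers for stronger inhibition), a limit of the assay.
Compound 2 `Cc1nn(C)c(Oc2ccc(F)cc2F)c1/C=N\CCCCCCOc1cc2oc(=O)cc(C)c2cc1Cl`: > 25000 nM in this assay, a limit of the assay.
Compound 3 `Cc1nn(C)c(Oc2cccc(Br)c2)c1/C=N\CCCCCCOc1cc2oc(=O)cc(C)c2cc1Cl`: 3610 nM in this assay.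

Among the compounds with values here, compound 3 holds the only readable number in this assay; the other two values sit at the limit of > 25000 nM in this assay, at which 2 of the 3 values shown sit. The steps from compound 1 to compound 3 an at least 6.9-fold lower number from compound 1 to compound 3 (0.84 log units; beyond the scatter) and from compound 2 to compound 3 an at least 6.9-fold lower number from compound 2 to compound 3 (0.84 log units; beyond the scatter) are both read against that limit, so their true size is not known beyond the lower bound. The step from compound 1 to compound 2 a step that the two limits leave unreadable from compound 1 to compound 2 is unreadable.

Compound 4 `Cc1ccccc1Oc1c(/C=N\CCCCCCOc2cc3oc(=O)cc(C)c3cc2Cl)c(C)nn1C` differs from compound 3 by 2-methylphenyl in place of 3-bromophenyl on an oxygen on an aromatic ring. The 3-bromophenyl is the only aryl ether among the three that gave a number; the 2-fluorophenyl of compound 1 and the 2,4-difluorophenyl of compound 2 both returned a limit. Removing the 3-bromophenyl is therefore expected to move compound 4 back toward the limit, with the step of a 3.3-fold higher number from compound 3 to compound 4 (0.52 log units; beyond the scatter) expected upward, though the 2-methylphenyl itself has no measured neighbour here. Compound 4 is expected at 12000 nM in this assay, in the range 3500 nM to 40000 nM.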

Compound 4, half-maximal inhibitory concentration: 9610 nM
Compound 4: middle estimate off by 1.2-fold (0.10 log units), on the high side; the range from low to high includes it.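

In this assay, within the data shown here, the step of a 2.7-fold higher number from compound 3 to compound 4 (0.43 log units; beyond the scatter) is the first change at this position with a readable number at both ends, and the 3-bromophenyl keeps the lower value. The 2-methylphenyl also gives a readable number, so a measurable value here does not rest on the 3-bromophenyl alone, and methyl in place of fluoro on an aromatic carbon gives an at least 2.6-fold lower number from compound 1 to compound 4 (0.41 log units; beyond the scatter), while the change from the 2,4-difluorophenyl gives an at least 2.6-fold lower number from compound 2 to compound 4 (0.41 log units; beyond the scatter). Both of these steps are lower bounds, as compound 1 and compound 2 each stand at a limit: the limit of > 25000 nM in this assay, at which 2 of the 4 values shown sit.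

As far as these compounds go, whether the gap between compound 3 and compound 4 follows the bromine or its place on the ring stays open. An unsubstituted phenyl, a 3-methylphenyl or a 2-bromophenyl on the same oxygen would separate those two readings.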